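This account rests on a few compounds, and the source may have more. Where it says the series, first, only, none or still open, it means among the compounds named here.

For the measured compounds named here, in a functional assay on HUVEC cells (Homo sapiens) for inhibition (a higher number here means a weaker inhibitor, a lower number a stronger inhibitor), compound 1 (`CN(c1ccc(N/C(S)=N/c2ccccc2)cc1)c1ccnc(Nc2cccc(CS(C)(=O)=O)c2)n1`) gives 6 nM, the lower of the two numbers so far, while compound 2 (`CN(c1ccc(NC(=O)Nc2ccc(OC(F)(F)F)cc2)cc1)c1ccnc(Nc2ccc(S(N)(=O)=O)cc2)n1`) gives 37 nM, a gap beyond the scatter. These two compounds differ in more than one place, so their gap says nothing about any single change.

Compound 3 (`CCCCNC(=O)Nc1ccc(N(C)c2ccnc(Nc3cccc(CS(C)(=O)=O)c3)n2)cc1`) shares the core of compound 1 and differs from it in one place: a group of 7 heavy atoms (5 carbon, 1 nitrogen, 1 oxygen; no ring) in place of a group of 9 heavy atoms (7 carbon, 1 nitrogen, 1 sulfur; one six-membered aromatic ring of carbon only), on a nitrogen on an aromatic ring. Going by the values given here, no measured pair covers this change, so any expectation rests on thin ground.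

With compound 1 at 6 nM, the low end of the numbers seen so far, a higher number is expected in this assay, probably beyond the scatter, though a step within the scatter cannot be excluded. The expected size is a 5.0-fold higher number from compound 1 to compound 3 (0.70 log units; beyond the scatter). For compound 3 the estimate is 30 nM, with an expected range from 8 nM to 120 nM.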

Compound 3, half-maximal inhibitory concentration: 2 nM
For compound 3 the middle estimate is 15-fold (1.18 log units) above the measured one, outside the stated range (below it).
By their numbers in this assay, from the lowest: compound 3; then compound 1; then compound 2.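

On the nitrogen on an aromatic ring, butylcarbamoyl takes the place of the group carrying the six-membered aromatic ring, and in this assay this gives a 3.0-fold lower number from compound 1 to compound 3 (0.48 log units; beyond the scatter). For this pair, then, the aromatic ring of compound 1 is not needed for a low number at this position, and a group with no ring gives a lower number while the hydrogen-bond donor and acceptor counts of the group stay the same. Nothing at hand accounts for the size or direction of this step.

Going by these compounds, whether a longer chain, a shorter chain or a chain ending in an amine would keep or lower the number stays open. One step also cannot show whether butylcarbamoyl would give a similar step on the core of compound 2.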